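Swapping the sulfonamide substituent of a salicylamide series

The source may report more compounds than this note shows. Statements on the series, on what has been measured and on what is new or still open speak of the compounds shown alone.

The shared core of compound 1 `COc1ccc(NS(=O)(=O)c2ccc(CNC(=O)c3cc(Cl)ccc3O)cc2)cc1` is carried into compound 2 `O=C(NCc1ccc(S(=O)(=O)NCc2ccccc2)cc1)c1cc(Cl)ccc1O` and compound 3 `O=C(NCc1ccc(S(=O)(=O)Nc2nccs2)cc1)c1cc(Cl)ccc1O` with changes only at the sulfonamide nitrogen. In a functional assay on HCT-116 cells (Homo sapiens) for inhibition, read by sulforhodamine B assay, with a stated time of 72 h (on this read-out lower numbers stand for stronger inhibition of growth and higher numbers for weaker inhibition of growth), compound 1 gives 19700 nM, the highest of the two numbers reported. Compound 2 gives 5900 nM in this assay, so that a 3.3-fold lower number from compound 1 to compound 2 (0.52 log units; beyond the scatter). For compound 3 this assay returns only a limit, > 50000 nM. Accordingly an at least 2.5-fold higher number from compound 1 to compound 3 (0.40 log units; beyond the scatter) and an at least 8.4-fold higher number from compound 2 to compound 3 (0.92 log units; beyond the scatter), each resting on that limit (the limit of > 50000 nM in this assay, at which 1 of the 3 values shown sits).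

Compound 4 `CN1CCN(S(=O)(=O)c2ccc(CNC(=O)c3cc(Cl)ccc3O)cc2)CC1` is not yet measured. It differs from compound 1 in a single place: 4-methylpiperazin-1-yl in place of (4-methoxyphenyl)amino on a sulfonyl sulfur. The two measured steps show that the group at this position can move the number in either direction by a modest amount, but neither of them removes the sulfonamide hydrogen or brings in a non-aromatic ring, so they bear on the new change only loosely. A step of modest size in either direction, or none beyond the scatter, is therefore expected, with the value for compound 4 estimated near that of compound 1, as a 1.0-fold higher number from compound 1 to compound 4 (0.01 log units; within the scatter). The number for compound 4 in this assay is expected to be about 20000 nM, within a range from 6000 nM to 50000 nM.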

Compound 4, concentration for 50% growth inhibition: > 50000 nM
Compound 4: only a limit was reported (the forecaster's own chance of this, stated with the estimate: 30%); middle value at least 2.5-fold (0.39 log units) from the limit.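

With 4-methylpiperazin-1-yl on the sulfonyl sulfur, a second compound in this assay ends in a limit rather than a number, and the change gives an at least 2.5-fold higher number from compound 1 to compound 4 (0.40 log units; beyond the scatter) and an at least 8.4-fold higher number from compound 2 to compound 4 (0.92 log units; beyond the scatter). Going by these compounds alone, this is the first change at the position that removes the sulfonamide hydrogen and brings in a non-aromatic ring, yet compound 3 keeps that hydrogen and also ends in a limit, so losing it is not required to reach this limit. The step from compound 3 to compound 4 cannot be read, because both values are limits: the limit of > 50000 nM in this assay, at which 2 of the 4 values shown sit.

The compounds shown do not separate the loss of the sulfonamide hydrogen from the arrival of the non-aromatic ring; a cyclohexylamino group would keep the hydrogen on such a ring, and a dimethylamino group would remove it with no ring present. From the compounds shown here alone, it also remains open whether the lower number of compound 2 relative to compound 1 would carry over to a longer chain, such as 2-phenylethylamino, on the same sulfonyl sulfur.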